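A few compounds are considered here, and "the series" means these few. Any claim that something is new, unique, unknown or untested is made for them only; others in the source may bear on it.

Measured so far:
Compound 1 `COC(=O)/C=C/c1cccc(N(Cc2ccc(-c3cccc(C(C)=O)c3)cc2)C(=O)C2CCCCC2)c1` gives 227 nM in an assay on isolated protein with Bile acid receptor (Homo sapiens) as the target; a higher number here means that more compound is needed for the effect, a lower number that less compound is needed.
Compound 2 `COC(=O)/C=C/c1cccc(N(Cc2ccc(/C=C/c3c(Cl)cccc3Cl)cc2)C(=O)C2CCCCC2)c1` gives 150 nM in this assay.

For the measured compounds named here, only two numbers are known, and they lie close together: the step of a 1.5-fold lower number from compound 1 to compound 2 (0.18 log units; within the scatter) did not reach beyond the usual scatter, so compound 2 and compound 1 cannot be told apart on potency. Compound 2 is simply the one from which the next step is taken.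

Compound 3 `COC(=O)/C=C/c1cccc(N(Cc2ccc(/C=C/c3ccc(F)cc3)cc2)C(=O)C2CCCCC2)c1` differs from compound 2 in one place: 4-fluorophenyl in place of 2,6-dichlorophenyl on a double-bonded chain carbon bound to a double-bonded chain carbon. Going by the values given here, the only measured step that touches this part of the molecule is the one in which the whole 2-(2,6-dichlorophenyl)ethenyl group entered in place of 3-acetylphenyl, and that step, a 1.5-fold lower number from compound 1 to compound 2 (0.18 log units; within the scatter), stayed within the scatter. The new change is smaller, swapping one aromatic ring for another at the end of the same chain. With so little to go on, no shift beyond the scatter is expected in this assay, and the uncertainty is wide.

For compound 3 the expected step is a 1.2-fold higher number from compound 2 to compound 3 (0.08 log units; within the scatter), giving an estimate of 180 nM with a likely range from 60 nM to 550 nM.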

Compound 3, half-maximal effective concentration: 185 nM
Beside the measured number, compound 3's estimate is 1.0-fold (0.01 log units) below it; the measured number falls inside the stated range.
By their numbers in this assay, from the lowest: compounds 2, 3 and 1 (each within the scatter of the next).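

In this assay the ring on the double-bonded chain carbon can be exchanged without a readable effect: 4-fluorophenyl in place of 2,6-dichlorophenyl gives a 1.2-fold higher number from compound 2 to compound 3 (0.09 log units; within the scatter) and stays within the scatter, so this position accepts both of these halogen-bearing phenyl rings. The comparison with the directly attached group, 2-(4-fluorophenyl)ethenyl in place of 3-acetylphenyl on an aromatic carbon, gives a 1.2-fold lower number from compound 1 to compound 3 (0.09 log units; within the scatter) and also stays within the scatter, so two different ethenyl-linked groups now match 3-acetylphenyl and the three compounds cannot be ranked. No independent measurement is available that would explain why these groups read alike.

Still open, as far as these compounds go, is whether a ring carrying an amine or a carboxylic acid, or a longer chain with no ring at all, would move the number in this assay beyond the scatter at this position. The shared core is the same in all three compounds, so what its other parts contribute cannot be read from them.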